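A few compounds are considered here, and "the series" means these few. Any claim that something is new, unique, unknown or untested is made for them only; others in the source may bear on it.

Compound 1 `NC(=O)c1cccc(Cn2cc(-c3ccc4cn[nH]c4c3)ccc2=O)c1` gives 388 nM in an assay for inhibition of MAP kinase-interacting serine/threonine-protein kinase 1 (Homo sapiens), read by luminescence and ADP-Glo, with a stated time of 2 h (a higher number here means a weaker inhibitor, a lower number a stronger inhibitor), the only number shown there. For compound 2 `O=c1ccc(-c2ccc3cc[nH]c3c2)cn1Cc1ccccc1`, this assay reports only a limit, > 2000 nM. That is the limit of > 2000 nM in this assay, at which 1 of the 2 values shown sits. Compound 3 `Nc1cccc(Cn2cc(-c3ccc4cn[nH]c4c3)ccc2=O)c1` differs from compound 1 by amino in place of carbamoyl on an aromatic carbon. No step between measured compounds is shown for this change, so no measured comparison guides it. A modest weakening, beyond the usual scatter, is expected for compound 3, estimated as a 2.6-fold higher number from compound 1 to compound 3 (0.41 log units; beyond the scatter). Compound 3 is therefore expected to give about 1000 nM in this assay, with a range from 300 nM to 3000 nM.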

Compound 3, half-maximal inhibitory concentration: 287 nM
The estimate for compound 3 lay 3.5-fold (0.54 log units) above the measured number, and the stated range ends above it.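

In this assay, this first measured step at this position puts amino in place of carbamoyl with a 1.4-fold lower number from compound 1 to compound 3 (0.13 log units; within the scatter), so the two groups cannot be told apart here. The carbamoyl of compound 1 is therefore not required at this position, since amino, with one heavy atom against three, serves equally well in compound 3. Nothing shown gives a reason for this match. The compounds shown leave open whether a carboxylic acid, a methoxy group or an aminomethyl group would fare the same at this position.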